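Swapping a pyrrole for a pyridine on the amide of compound 3

This account rests on a few compounds, and the source may have more. Where it says the series, first, only, none or still open, it means among the compounds named here.

Of the compounds shown here, three sharing one core have been measured in a functional assay on Vas deferens for antagonist activity at Alpha-1A adrenergic receptor (Rattus norvegicus); a lower number here means a less potent compound, a higher number a more potent compound, by a factor of ten per unit of this negative logarithm. Compound 1 `COc1cc2nc(N3CCN(C(=O)c4ccc(Br)o4)[C@H]4CCCC[C@H]43)nc(N)c2cc1OC` gives 7.53, compound 2 `COc1cc2nc(N3CCN(C(=O)c4ccc(C(C)=O)o4)[C@H]4CCCC[C@H]43)nc(N)c2cc1OC` gives 7.05, and compound 3 `COc1cc2nc(N3CCN(C(=O)c4ccc[nH]4)[C@H]4CCCC[C@H]43)nc(N)c2cc1OC` gives 7.06. Compound 3 thus sits second highest of the three: its value and that of compound 2 lie within the usual scatter of each other, while compound 1 stands apart, as the step of a number 0.47 log units lower from compound 1 to compound 3 (beyond the scatter) shows.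

The next compound, compound 4 `COc1cc2nc(N3CCN(C(=O)c4ccccn4)[C@H]4CCCC[C@H]43)nc(N)c2cc1OC`, differs from compound 3 only at the amide: pyridin-2-yl in place of 1H-pyrrol-2-yl on a carbonyl carbon. For the measured compounds named here, no measured step involves a pyridine, so the expectation leans on the two steps that touch the same carbonyl carbon: a number 0.47 log units lower from compound 1 to compound 3 (beyond the scatter) and a number 0.01 log units higher from compound 2 to compound 3 (within the scatter). Exchanging the aromatic ring at this position has therefore produced either a modest loss or no change beyond the scatter. With no closer guide, the step of a number 0.06 log units lower from compound 3 to compound 4 (within the scatter) is expected to be small and could go either way.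

Compound 4 is therefore estimated at 7 in this assay, with a likely range from 6.4 to 7.6.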

Compound 4, negative logarithm of the antagonist equilibrium constant: 7.04
Compound 4: the middle estimate sits 0.04 log units below what was measured, within the range that was stated.
By their numbers in this assay, from the lowest: compounds 4, 2 and 3 (each within the scatter of the next); then compound 1.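

In this assay, the step of a number 0.02 log units lower from compound 3 to compound 4 (within the scatter) shows that a six-membered aromatic ring can stand on this carbonyl carbon in place of a five-membered one, and that 1 hydrogen-bond donor with 0 acceptors can give way to 0 donors with 1 acceptor, while the two values remain indistinguishable. The step of a number 0.01 log units lower from compound 2 to compound 4 (within the scatter) places compound 4 with compound 2 as well, so three quite different aromatic groups now give values that cannot be told apart, whereas the step of a number 0.49 log units lower from compound 1 to compound 4 (beyond the scatter) confirms that the 5-bromofuran-2-yl group of compound 1 is the only one of the four to stand apart. Nothing available explains why these rings give such similar values or why compound 1 differs.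

The compounds shown leave open whether the ring nitrogen of pyridin-2-yl matters at all, a question that a plain phenyl ring or a pyridin-3-yl group on the same carbonyl carbon would address. They also leave open whether the bromine or the furan ring sets compound 1 apart, which an unsubstituted furan-2-yl group would help to separate.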